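Trading an aminopropyl chain for a pyrrolidine ring

The source may hold more compounds than are shown below. What is called first, only, known or untested is meant among the compounds shown, and "the series" means these compounds.

Of the compounds shown here, two have been measured in an assay on L1.2 cells for binding affinity to C-C chemokine receptor type 8 (Homo sapiens); on this read-out lower numbers stand for stronger inhibition and higher numbers for weaker inhibition. Compound 1 `CCOC(=O)N1CCC(NS(=O)(=O)c2ccc(NC(=O)c3ccccc3)c3ccccc23)CC1` gives 0.17 nM, while compound 2 `Cc1ccccc1C(=O)Nc1ccc(S(=O)(=O)NC2CCN(C(=O)CCCN)CC2)c2ccccc12` gives 1.6 nM, the higher of the two numbers, and the gap between them lies beyond the scatter. Compound 3 `Cc1ccccc1C(=O)Nc1ccc(S(=O)(=O)NC2CCN(C(=O)N3CCCC3)CC2)c2ccccc12` differs from compound 2 in one place: pyrrolidin-1-yl in place of 3-aminopropyl on a carbonyl carbon. Among the measured compounds shown here, no measured pair shows this change, so its effect is open. Because compound 1 reaches 0.17 nM, compound 3 is expected to come in lower than compound 2, by a step of a 3.2-fold lower number from compound 2 to compound 3 (0.51 log units; beyond the scatter). The estimate for compound 3 is 0.5 nM, within a range from 0.15 nM to 2 nM.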

Compound 3, inhibition constant: 1.1 nM
Compound 3: middle estimate off by 2.2-fold (0.34 log units), on the low side; low and high end bracket the measured number.
By their numbers in this assay, from the lowest: compound 1; then compounds 3 and 2 (each within the scatter of the next).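

In this assay, this position on a carbonyl carbon accepts a very different group: putting pyrrolidin-1-yl in place of 3-aminopropyl gives a 1.5-fold lower number from compound 2 to compound 3 (0.16 log units; within the scatter) and so no readable change. The open chain with its hydrogen-bond donor and acceptor can therefore give way to a ring with neither, at least in this pair, without moving the number past the scatter. No measured evidence explains this match. Going by these compounds, whether a larger piperidin-1-yl ring or a shorter 2-aminoethyl chain on the same carbonyl carbon would also leave the number level remains open.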